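The source may hold more compounds than are shown below. What is called first, only, known or untested is meant among the compounds shown, and "the series" means these compounds.

The measured compounds, all tested in a functional assay on A549 cells (Homo sapiens) for antiproliferative activity, read by MTT assay, with a stated time of 72 h; a higher number here means a weaker inhibitor, a lower number a stronger inhibitor:

compound 1, `CNC(=O)c1cc(Oc2ccc(NC(=O)c3cc4cccnc4n(-c4ccc(F)cc4)c3=O)cc2)ccn1`: 110 nM
compound 2, `CNC(=O)c1cc(Oc2ccc(NC(=O)c3cc4cccnc4n(-c4ccc(OC)cc4)c3=O)cc2)ccn1`: 3110 nM
compound 3, `CNC(=O)c1cc(Oc2ccc(NC(=O)c3cc4cccnc4n(-c4ccc(Br)cc4F)c3=O)cc2)ccn1`: 1420 nM

Compound 3 stands second highest of the three numbers in this assay. Its distance from the lowest number is the step of a 13-fold higher number from compound 1 to compound 3 (1.11 log units; beyond the scatter), and its distance from the highest is the step of a 2.2-fold lower number from compound 2 to compound 3 (0.34 log units; beyond the scatter). Every one of these measured steps, including a 28-fold higher number from compound 1 to compound 2 (1.45 log units; beyond the scatter), changes the aryl group on the aromatic nitrogen of the shared core; none of them touches the amide on the other end of the molecule.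

Compound 4, `CCCNC(=O)c1cc(Oc2ccc(NC(=O)c3cc4cccnc4n(-c4ccc(Br)cc4F)c3=O)cc2)ccn1`, differs from compound 3 only there: ethyl in place of hydrogen on a saturated chain carbon bound to an amide-type nitrogen. Among the compounds with values here, no measured step bears on this change, so the expectation rests on the fact that the one region of the molecule varied so far lies elsewhere and is held constant between compound 3 and compound 4. On that basis the step of a 1.3-fold higher number from compound 3 to compound 4 (0.10 log units; within the scatter) is expected to be small, with no direction that can be called beyond the scatter. Compound 4 is therefore estimated to give about 1800 nM, with a likely range from 500 nM to 6500 nM.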

Compound 4, half-maximal inhibitory concentration: 1310 nM
The estimate for compound 4 lay 1.4-fold (0.14 log units) above the measured number; the range from low to high includes it.
By their numbers in this assay, from the lowest: compound 1; then compounds 4 and 3 (each within the scatter of the next); then compound 2.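

In this assay the change from methylcarbamoyl to propylcarbamoyl gives a 1.1-fold lower number from compound 3 to compound 4 (0.04 log units; within the scatter), so at this place, with the 4-bromo-2-fluorophenyl group held constant, adding ethyl leaves a difference that cannot be told from the scatter. Within the data shown here, the earlier compounds showed only the aryl group on the aromatic nitrogen being varied, and each of those steps lay beyond the scatter, among them a 13-fold higher number from compound 1 to compound 3 (1.11 log units; beyond the scatter), so this is the first sign that the amide end of the molecule can carry a longer chain with no measurable difference in this one comparison. Nothing measured here explains why the methylcarbamoyl and propylcarbamoyl compounds read alike.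

The compounds shown leave open whether a chain longer than propyl, or a chain ending in an amine or a carboxylic acid, would also read like compound 3. Among these compounds, they also leave open whether propylcarbamoyl would read the same alongside the 4-fluorophenyl group of compound 1 , which gives 110 nM, since this change appears with only one aryl group.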